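This account rests on a few compounds, and the source may have more. Where it says the series, first, only, none or still open, it means among the compounds named here.

In a functional assay on MCF7 cells (Homo sapiens) for cytotoxicity, read by MTT assay, with a stated time of 96 h (on this read-out higher numbers stand for weaker inhibition and lower numbers for stronger inhibition), three compounds have been measured so far. Compound 1 `COc1cc(C(=O)c2cn(-c3cccc(C)c3)cc2-c2ccc(N)cc2)cc(OC)c1OC` gives 18 nM. Compound 2 `COc1cc(C(=O)c2cn(-c3ccc(C)cc3)cc2-c2ccc(N)cc2)cc(OC)c1OC` gives 6 nM, and the move between them is small to modest: a 3.0-fold lower number from compound 1 to compound 2 (0.48 log units; beyond the scatter), with 4-methylphenyl in place of 3-methylphenyl on an aromatic nitrogen. Compound 3 `COc1cc(C(=O)c2cn(-c3ccc(F)cc3)cc2-c2cccc([N+](=O)[O-])c2)cc(OC)c1OC` gives 440 nM, the highest number of the three and the weakest inhibition, beyond the scatter from both of the others.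

Compound 4 `COc1cc(C(=O)c2cn(-c3ccc(F)cc3)cc2-c2ccc(N)cc2)cc(OC)c1OC` is still unmeasured. It keeps the 4-fluorophenyl group of compound 3 and carries 4-aminophenyl in place of 3-nitrophenyl on an aromatic carbon. Going by the values given here, no measured step covers this change directly, and the single step available lies at the other position, so it serves only as a guide to how much the group on the ring nitrogen can move the number. The better guide is that compound 1 and compound 2 both carry 4-aminophenyl and both sit far lower than compound 3. A large step towards a lower number is therefore expected in this assay, estimated as a 29-fold lower number from compound 3 to compound 4 (1.47 log units; beyond the scatter). For compound 4 the expected value is 15 nM, with an estimated range of 4 nM to 60 nM.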

Compound 4, half-maximal inhibitory concentration: 12 nM
Beside the measured number, compound 4's estimate is 1.3-fold (0.10 log units) above it; the range from low to high includes it.
By their numbers in this assay, from the lowest: compounds 2, 4 and 1 (each within the scatter of the next, the first and the last beyond it); then compound 3.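

In this assay, going by these compounds alone, the exchange of 3-nitrophenyl for 4-aminophenyl on the aromatic carbon gives the first measured step at this position (a 37-fold lower number from compound 3 to compound 4 (1.56 log units; beyond the scatter)), and it is large. With 4-aminophenyl held in place, the group on the ring nitrogen is now seen in a third form: 4-fluorophenyl cannot be told apart from 4-methylphenyl (a 2.0-fold higher number from compound 2 to compound 4 (0.30 log units; within the scatter)) or from 3-methylphenyl (a 1.5-fold lower number from compound 1 to compound 4 (0.18 log units; within the scatter)), as both steps lie within the scatter. Among these compounds the only step at the ring nitrogen beyond the scatter remains the modest one between the two methylphenyl groups (a 3.0-fold lower number from compound 1 to compound 2 (0.48 log units; beyond the scatter)), so the aromatic carbon carries the largest step seen so far.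

The step from 3-nitrophenyl to 4-aminophenyl changes both the group on the phenyl ring and where it sits, and the effects of these two changes stay unseparated until 3-aminophenyl or 4-nitrophenyl is compared at this position with the 4-fluorophenyl group kept. Nothing available explains the size of this step, and other replacements, such as 4-hydroxyphenyl, remain open as well.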